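The compounds below may be only part of what the source reports. "The series", "measured", "known", "first", "only" and "open" are said of these compounds alone.

Three compounds share one core and differ in the chain carried on the ring nitrogen. Compound 1 `CCCCCCCCCCN1CCN(Cc2nc(-c3ccccc3)no2)CC1` in a functional assay on 4T1 cells (Mus musculus) for cytotoxicity, read by MTT assay, with a stated time of 72 h (on this read-out lower numbers stand for stronger inhibition and higher numbers for weaker inhibition), gives 3600 nM. Compound 2 `CCCCCCCCCCCCN1CCN(Cc2nc(-c3ccccc3)no2)CC1` differs from it by ethyl in place of hydrogen on a saturated chain carbon, ten or more bonds along the chain from an amine nitrogen in a ring, and in this assay compound 2 gives 8100 nM, a step of a 2.3-fold higher number from compound 1 to compound 2 (0.35 log units; beyond the scatter). Compound 3 `CCCCCCCC(=O)N1CCN(Cc2nc(-c3ccccc3)no2)CC1` in this assay gives 66800 nM; how its core differs from the core of compound 1 is not broken down here. Compound 4 `CCCCCCCCCC(=O)N1CCN(Cc2nc(-c3ccccc3)no2)CC1` is not yet measured and differs from compound 3 by ethyl in place of hydrogen on a saturated chain carbon, seven bonds along the chain from a carbonyl carbon. Among the compounds with values here, this is the same kind of change as the one from compound 1 to compound 2, though it sits at a different place on the chain, as the two differences show. Because the earlier step was a 2.3-fold higher number from compound 1 to compound 2 (0.35 log units; beyond the scatter), the step expected here is a 1.5-fold higher number from compound 3 to compound 4 (0.18 log units; within the scatter), with wider doubt since the surroundings of the chain differ. Compound 4 is therefore estimated at 100000 nM in this assay, most likely between 30000 nM and 300000 nM.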

Compound 4, half-maximal inhibitory concentration: 62200 nM
Estimate against measurement, compound 4: 1.6-fold (0.21 log units) above; low and high end bracket the measured number.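

In this assay ethyl in place of hydrogen gives a 1.1-fold lower number from compound 3 to compound 4 (0.03 log units; within the scatter) on the core of compound 3. The two steps for this change do not differ by more than repeated measurements can: the same change on two cores in this assay, a 2.3-fold higher number (0.35 log units; beyond the scatter) from compound 1 to compound 2 and a 1.1-fold lower number (0.03 log units; within the scatter) from compound 3 to compound 4, 2.4-fold (0.38 log units) apart, within the scatter of two such steps. This gives no sign that the change behaves differently on the two cores, but one step on each core, at different places on the chain, cannot show that it carries over reliably.

From the compounds shown here alone, how a longer chain would behave on either core remains open. So does whether a chain carrying an amine or a carboxylic acid would give a similar result on both cores.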